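Notes on a sulfonamide side-chain series: compound 4

The source may hold more compounds than are shown below. What is called first, only, known or untested is meant among the compounds shown, and "the series" means these compounds.

In a physicochemical assay for lipophilicity (a higher number here means a more lipophilic compound, a lower number a more polar compound), the measured compounds give:
compound 1, `CCN(CC)CCCn1cc[n+](C)c1/C=N/O`: -2.78
compound 2, `CN(CCCn1cc[n+](C)c1/C=N/O)S(C)(=O)=O`: -2.63
compound 3, `CCN(CCCn1cc[n+](C)c1/C=N/O)S(C)(=O)=O`: -2.69

Compound 2 cannot be separated from the other two: a number 0.15 log units higher from compound 1 to compound 2 (within the scatter) and a number 0.06 log units lower from compound 2 to compound 3 (within the scatter). Compound 4, `CN(CCCn1cc[n+](C)c1/C=N/O)S(=O)(=O)c1ccccc1`, differs from compound 2 by phenyl in place of methyl on a sulfonyl sulfur. Among the compounds with values here, no measured step exchanges an alkyl for an aryl group; the measured steps rework only the amine end of the chain, including a number 0.09 log units higher from compound 1 to compound 3 (within the scatter), and none leaves the scatter. The expectation therefore rests on the size of the group entering rather than on a measured precedent. For compound 4 a rise beyond the scatter is expected, a number 1.03 log units higher from compound 2 to compound 4 (beyond the scatter). The estimate for compound 4 is -1.6, with a range of -2.4 to -0.9.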

Compound 4, distribution coefficient: -1.59
Compound 4: middle estimate off by 0.01 log units, on the low side; the range from low to high includes it.
By their numbers in this assay, from the lowest: compounds 1, 3 and 2 (each within the scatter of the next); then compound 4.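

Within the data shown here, the sulfonyl sulfur is the first place where a single change leaves the scatter in this assay: phenyl in place of methyl gives a number 1.04 log units higher from compound 2 to compound 4 (beyond the scatter), while the steps among compound 1, compound 2 and compound 3 all stay within it. Neither group carries a hydrogen-bond donor, a hydrogen-bond acceptor or a net charge; the entering group adds a six-membered aromatic ring of carbon only. Nothing available accounts for the size of this step.

Open, on these data alone, is whether a cyclohexyl or butyl group on the sulfonyl sulfur would give a step of similar size. Also open, as far as these compounds go, is what a pyridyl ring at that position would give.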